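From Fluoro to Chloro: Predicting Compound 4

The compounds below may be only part of what the source reports. "The series", "measured", "known", "first", "only" and "open" are said of these compounds alone.

Compound 1 `Cc1ccccc1-c1nnc(SCc2ccc(Cl)nc2)o1`: 8.51 ug/mL
Compound 2 `Cc1ccc(-c2nnc(SCc3ccc(Cl)nc3)o2)cc1`: 3.62 ug/mL
Compound 3 `Fc1ccccc1-c1nnc(SCc2ccc(Cl)nc2)o1`: 9.12 ug/mL

Three compounds sharing one core have been run in a functional assay on SGC-7901 cells (Homo sapiens) for antiproliferative activity, read by MTT assay, with a stated time of 48 h; on this read-out lower numbers stand for stronger inhibition and higher numbers for weaker inhibition. Compound 3 stands at the highest number of the three; compound 1 lies within the scatter of it, and compound 2 sits furthest off, with a 2.5-fold higher number from compound 2 to compound 3 (0.40 log units; beyond the scatter). The comparison from compound 1 to compound 3 shows that fluoro in place of methyl barely moves the read-out, a 1.1-fold higher number from compound 1 to compound 3 (0.03 log units; within the scatter), whereas the comparison a 2.4-fold lower number from compound 1 to compound 2 (0.37 log units; beyond the scatter) shows that the 4-methylphenyl arrangement gives a modestly lower number than 2-methylphenyl.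

Compound 4 `Clc1ccc(-c2nnc(SCc3ccc(Cl)nc3)o2)cc1` has not yet been measured. It differs from compound 3 in one place: 4-chlorophenyl in place of 2-fluorophenyl on an aromatic carbon. For the measured compounds named here, no measured step covers a change of halogen, and none covers a move of a halogen on this ring. The closest guide is that the two groups on this ring which differ only in placement, in compound 1 and compound 2, gave a 2.4-fold lower number from compound 1 to compound 2 (0.37 log units; beyond the scatter). A step of similar size and direction is expected for a 2.5-fold lower number from compound 3 to compound 4 (0.40 log units; beyond the scatter), so compound 4 is estimated at 3.6 ug/mL, with a range from 1.6 ug/mL to 8.5 ug/mL.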

Compound 4, half-maximal inhibitory concentration: 8.62 ug/mL
Beside the measured number, compound 4's estimate is 2.4-fold (0.38 log units) below it; measured number above the stated range.
By their numbers in this assay, from the lowest: compound 2; then compounds 1, 4 and 3 (each within the scatter of the next).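

In this assay 4-chlorophenyl in place of 2-fluorophenyl on this aromatic carbon leaves the read-out within the scatter, with a 1.1-fold lower number from compound 3 to compound 4 (0.02 log units; within the scatter), and 4-chlorophenyl in place of 2-methylphenyl does the same, with a 1.0-fold higher number from compound 1 to compound 4 (0.01 log units; within the scatter). The 4-methylphenyl group of compound 2 therefore does not simply extend to another group named at the same place: chloro in place of methyl gives a 2.4-fold higher number from compound 2 to compound 4 (0.38 log units; beyond the scatter), which leaves compound 2 alone with the lowest number of the four. Nothing available accounts for why chloro and methyl part here while the other changes at this position stay within the scatter.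

The compounds shown leave halogen identity and placement tangled, since compound 3 and compound 4 differ in both, and neither 4-fluorophenyl nor 2-chlorophenyl stands among them to separate the two. They also leave open whether the lower number of compound 2 belongs to methyl alone or would persist with an ethyl chain, an amine or a carboxylic acid in place of that methyl.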